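This account rests on a few compounds, and the source may have more. Where it says the series, first, only, none or still open, it means among the compounds named here.

Measured compounds:

Compound 1, `COc1ncnc2c1c(-c1cccs1)cn2[C@@H]1O[C@H](CO)[C@@H](O)[C@H]1O`, gives 1760 nM in a functional assay on HeLa S3 cells (Homo sapiens) for antiproliferative activity, read by XTT assay, with a stated time of 72 h; on this read-out lower numbers stand for stronger inhibition and higher numbers for weaker inhibition.
Compound 2, `COc1ncnc2c1c(-c1ccccc1)cn2[C@@H]1O[C@H](CO)[C@@H](O)[C@H]1O`, in this assay reaches only the limit of > 20000 nM, which is a boundary of the measurement rather than a number.
Compound 3, `CNc1ncnc2c1c(-c1ccccc1)cn2[C@@H]1O[C@H](CO)[C@@H](O)[C@H]1O`, in this assay likewise reaches only the limit of > 20000 nM.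

The three compounds share one core; compounds 2 and 3 differ only at a single point, described as methylamino in place of methoxy on an aromatic carbon. That change gives a step that the two limits leave unreadable from compound 2 to compound 3, since both values sit at the limit of > 20000 nM in this assay, at which 2 of the 3 values shown sit.

Compounds 2 and 1 differ as thiophen-2-yl in place of phenyl on an aromatic carbon. This change produced an at least 11-fold lower number from compound 2 to compound 1 (1.05 log units; beyond the scatter), though the size of that step can only be read as a minimum.

Compound 4, `CNc1ncnc2c1c(-c1cccs1)cn2[C@@H]1O[C@H](CO)[C@@H](O)[C@H]1O`, has not yet been measured in this assay. For the measured compounds named here, its relation to compound 3 is thiophen-2-yl in place of phenyl on an aromatic carbon, the same change as the one from compound 2 to compound 1, made at the same place. Compound 3 carries the methylamino group, compound 2 the methoxy group, and both sit at the limit, so it is not known whether that group alters how the thiophene substitution plays out.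

For compound 4 the step from compound 3 is expected to be about an at least 8.0-fold lower number from compound 3 to compound 4 (0.90 log units; beyond the scatter), resting on the step of an at least 11-fold lower number from compound 2 to compound 1 (1.05 log units; beyond the scatter) measured on the methoxy pair. The expected value for compound 4 in this assay is therefore 2500 nM, with a likely span from 600 nM to 15000 nM.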

Compound 4, half-maximal inhibitory concentration: > 20000 nM
Compound 4 gave a limit, no number (the forecaster's own chance of this, stated with the estimate: 25%); at least 8.0-fold (0.90 log units) between middle value and limit.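

In this assay compound 4 reaches only > 20000 nM, which is a limit and not a number. Thiophen-2-yl in place of phenyl gave a measurable value on the methoxy core, but the same change on the methylamino core gave none, and methylamino in place of methoxy on the thiophene-bearing core produced an at least 11-fold higher number from compound 1 to compound 4 (1.05 log units; beyond the scatter). So the improvement seen on the methoxy pair did not carry over to the methylamino core as a readable value, yet this does not show that the change has no effect there, and it does not give the size of any effect, since the steps that join two limits cannot be read: the limit of > 20000 nM in this assay, at which 3 of the 4 values shown sit.

For the compounds shown here, of the four compounds, only the one that combines methoxy with thiophen-2-yl has a measured value, so two cores and two groups cannot show whether this is a narrow requirement or a broader trend. From the compounds shown here alone, it remains open whether a plain amino group or a dimethylamino group in place of methoxy would keep a readable value on the thiophene-bearing core, and whether furan-2-yl in place of thiophen-2-yl would do the same on the methoxy core.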